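A few compounds are considered here, and "the series" means these few. Any claim that something is new, unique, unknown or untested is made for them only; others in the source may bear on it.

Measured so far:
- compound 1, `CCCn1cc(C(N)=O)c2c(N)ncnc21`: 73000 nM
- compound 2, `Cn1cc(C(=N)S)c2c(N)ncnc21`: 38000 nM

In a functional assay on L1210 cells (Mus musculus) for inhibition (a lower number here means a stronger inhibitor, a higher number a weaker inhibitor), compound 1 gives 73000 nM. Compound 2 gives 38000 nM in this assay, and since the gap between compound 1 and compound 2 lies within the usual scatter, neither can be called the stronger inhibitor. Compound 3, `Cc1ccc(Cn2cc(C(N)=O)c3c(N)ncnc32)cc1`, differs from compound 1 by one change: 4-methylphenyl in place of ethyl on a saturated chain carbon bound to an aromatic nitrogen. Among the compounds with values here, no step of this kind has been measured here, so nothing in the data fixes its size. A moderate move toward a lower number is expected, with wide uncertainty, as a 2.4-fold lower number from compound 1 to compound 3 (0.39 log units; beyond the scatter). Compound 3 is therefore estimated at 30000 nM, within a range of 5000 nM to 150000 nM.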

Compound 3, half-maximal inhibitory concentration: 20000 nM
Compound 3: the middle estimate sits 1.5-fold (0.18 log units) above what was measured, within the range that was stated.
By their numbers in this assay, from the lowest: compounds 3, 2 and 1 (each within the scatter of the next, the first and the last beyond it).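

In this assay the change to 4-methylphenyl in place of ethyl on a saturated chain carbon bound to an aromatic nitrogen gives a 3.7-fold lower number from compound 1 to compound 3 (0.56 log units; beyond the scatter). This shows that the position tolerates a six-membered aromatic ring and that the number falls, though the step is modest and is the only one of its kind here. No available evidence explains this step. On these data alone, it remains open whether the ring or its methyl matters more, which plain phenyl would help to separate. A longer chain, such as hexyl, or an amine on the ring could also be informative.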